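This account rests on a few compounds, and the source may have more. Where it says the series, first, only, none or still open, it means among the compounds named here.

Measured so far in an assay on HEK293 cells for displacement of a labelled ligand from melanin-concentrating hormone receptor 1 (Homo sapiens); on this read-out lower numbers stand for stronger inhibition and higher numbers for weaker inhibition:
Compound 1, `O=C(COc1cccc(Cl)c1)NC1CCN(Cc2ccn(-c3ccccc3)c2)CC1`, gives 710 nM.
Compound 2, `COc1ccc(-n2ccc(CN3CCC(NC(=O)COc4cccc(Cl)c4)CC3)c2)cc1`, gives 100 nM.
Compound 3, `O=C(COc1cccc(Cl)c1)NC1CCN(Cc2ccn(C3CCCC3)c2)CC1`, gives only a limit of the assay, > 33000 nM.

Compound 3 thus stands at the weak end of the three, at the limit of > 33000 nM in this assay, at which 1 of the 3 values shown sits. Compound 4, `O=C(COc1cccc(Cl)c1)NC1CCN(Cc2ccn(-c3ccon3)c2)CC1`, differs from compound 3 in one place: 1,2-oxazol-3-yl in place of cyclopentyl on an aromatic nitrogen. For the measured compounds named here, no measured step makes exactly this change, but two bear on it: an at least 46-fold higher number from compound 1 to compound 3 (1.66 log units; beyond the scatter) and an at least 330-fold higher number from compound 2 to compound 3 (2.51 log units; beyond the scatter), both large, showing that replacing an aromatic ring on that nitrogen by cyclopentyl weakens binding greatly. Compound 4 puts an aromatic ring back on that nitrogen, though a smaller, two-hetero-atom ring rather than a benzene ring. A large step back towards stronger binding is therefore expected, an at least 22-fold lower number from compound 3 to compound 4 (1.34 log units; beyond the scatter). Compound 4 is estimated at 1500 nM, with a likely range from 300 nM to 10000 nM.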

Compound 4, half-maximal inhibitory concentration: 1500 nM
Compound 4: middle estimate and measured number agree at the digits printed; the range from low to high includes it.
By their numbers in this assay, from the lowest: compound 2; then compound 1; then compound 4. At a limit, above all of these: compound 3.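

Compound 3 stands at a limit of the assay: the limit of > 33000 nM in this assay, at which 1 of the 4 values shown sits. Even so, the change gives an at least 22-fold lower number from compound 3 to compound 4 (1.34 log units; beyond the scatter), so on this aromatic nitrogen an aromatic ring with two hetero atoms also binds far better than cyclopentyl, and a benzene ring is not required. The 1,2-oxazol-3-yl ring still falls short of the benzene rings, with a 2.1-fold higher number from compound 1 to compound 4 (0.32 log units; beyond the scatter) and, against the methoxy-bearing ring, a 15-fold higher number from compound 2 to compound 4 (1.18 log units; beyond the scatter). Left open is whether a methoxy group on the 1,2-oxazol-3-yl ring would also lower the number, and how a pyridyl or thienyl ring would compare on that nitrogen.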